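The source may report more compounds than this note shows. Statements on the series, on what has been measured and on what is new or still open speak of the compounds shown alone.

Compound 2 `COc1cc2c(CN3CCCC3)coc2cc1C` and compound 1 `COc1cc2c(CN(C)C)coc2cc1C` share one core and differ only in the amine carried on a saturated chain carbon bound to an aromatic carbon. In a functional assay on HEK293 cells for agonist activity at melatonin receptor type 1A (Homo sapiens), read by calcium flux (a higher number here means that more compound is needed for the effect, a lower number that less compound is needed), compound 1 gives 440000 nM, and in this assay compound 2 gives 310000 nM. Among the compounds with values here, the one measured step, a 1.4-fold lower number from compound 1 to compound 2 (0.15 log units; within the scatter), shows that the two numbers stand within the usual scatter of each other, so neither compound can be set apart from the other on these data.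

Compound 3 `COc1cc2c(CN3CCNCC3)coc2cc1C` is not yet measured. It differs from compound 2 by piperazin-1-yl in place of pyrrolidin-1-yl on a saturated chain carbon bound to an aromatic carbon. Within the data shown here, the only step that bears on this change is a 1.4-fold lower number from compound 1 to compound 2 (0.15 log units; within the scatter), which swapped one small amine for another on the same carbon and left the number essentially where it was. Among the measured compounds shown here, on that single precedent, the expected step of a 1.3-fold higher number from compound 2 to compound 3 (0.11 log units; within the scatter) is small, with no direction claimed beyond the scatter, and a wide range allowed because only one comparison exists. Compound 3 is therefore estimated at 400000 nM in this assay, between 150000 nM and 1000000 nM.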

Compound 3, half-maximal effective concentration: 460000 nM
The estimate for compound 3 lay 1.2-fold (0.06 log units) below the measured number; measured number inside the range.
By their numbers in this assay, from the lowest: compounds 2, 1 and 3 (each within the scatter of the next).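

Putting piperazin-1-yl in place of pyrrolidin-1-yl on a saturated chain carbon bound to an aromatic carbon brings in a six-membered ring with 2 hetero atoms and 1 hydrogen-bond donor, yet this assay shows only a 1.5-fold higher number from compound 2 to compound 3 (0.17 log units; within the scatter) for this change. Set against the open-chain amine, piperazin-1-yl gives a 1.0-fold higher number from compound 1 to compound 3 (0.02 log units; within the scatter), so dimethylamino, pyrrolidin-1-yl and piperazin-1-yl cannot be told apart at this position, even though they differ in ring size, hetero atoms and hydrogen-bond donors. No separate measurement bears on why these three amines read alike.

The compounds shown leave open whether a group of a different kind on this carbon, such as a carboxylic acid, an amide or a longer chain ending in an amine, would move the number beyond the scatter. They also leave open whether a change elsewhere on the shared core, for example to the methoxy or the methyl group, would matter more than the choice among these amines.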